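This account rests on a few compounds, and the source may have more. Where it says the series, first, only, none or still open, it means among the compounds named here.

Measured in an assay on Sf9 cells for inhibition of protein deacetylase HDAC6 (Homo sapiens), read by fluorescence, with a stated time of 40 min, tested at 100 nM; a higher number here means more inhibition at the concentration tested (going by the name of the read-out), a lower number less inhibition:
compound 1 `O=C(NO)c1ccc(NCc2nc(-c3ccc(Br)o3)nn2-c2ccccc2)cc1`: 55.8%
compound 2 `COc1ccc(-n2nc(-c3ccccc3)nc2CNc2ccc(C(=O)NO)cc2)cc1`: 63.4%
compound 3 `NNC(=O)c1ccc(NCc2nc(-c3ccccc3)nn2-c2ccccc2)cc1`: 10%

Compound 1 stands second highest of the three. Its nearest neighbour is compound 2, whose number lies within the scatter of compound 1, so no order can be read between them. Compound 3 lies far below both; its value and that of compound 1 are clearly apart, and the two structures differ in more than one place, so nothing more is drawn from that pair.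

Compound 4 `O=C(NO)c1ccc(NCc2nc(-c3ccncc3)nn2-c2ccccc2)cc1` differs from compound 1 in one place: pyridin-4-yl in place of 5-bromofuran-2-yl on an aromatic carbon. Among the measured compounds shown here, no measured pair shows this kind of change. The step is expected to stay within the scatter or to fall modestly, so that from compound 1 to compound 4 it is estimated at a number 5.8 percentage points lower from compound 1 to compound 4 (within the scatter). Compound 4 is thus expected to give 50%, between 25% and 72%.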

Compound 4, a percentage reported as inhibition, at one concentration (the size of the read-out at that concentration, not a potency): 30.8%
Compound 4: middle estimate off by 19.2 percentage points, on the high side, and the stated range covers the measured number.
By their numbers in this assay, from the lowest: compound 3; then compound 4; then compounds 1 and 2 (each within the scatter of the next).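

In this assay, the aromatic carbon between two ring nitrogen atoms proves sensitive to the group it carries: pyridin-4-yl in place of 5-bromofuran-2-yl gives a number 25 percentage points lower from compound 1 to compound 4 (beyond the scatter). Among the compounds shown here, this is the first one-place comparison at this position, and the two groups match in heavy atoms and hydrogen-bond acceptors, so those counts alone do not set the number. No measurement at hand accounts for this step. The compounds shown leave open whether the bromine, the ring size or the ring's hetero atom matters. Furan-2-yl without bromine or pyridin-3-yl at this carbon would bear on that.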